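The source may report more compounds than this note shows. Statements on the series, on what has been measured and on what is new or still open speak of the compounds shown alone.

Measured compounds:
- compound 1, `NC(N)=NC(=O)c1nc(Cl)c(NCc2ccccc2Cl)nc1N`, in an assay for inhibition of acid-sensing ion channel 3 (Homo sapiens), read by patch clamp, tested at 1 uM (on this read-out lower numbers stand for less inhibition and higher numbers for more inhibition at the one concentration tested (going by the name of the read-out)), compound 1 gives 31%
- compound 2, `CC(C)(C)Nc1nc(N)c(C(=O)N=C(N)N)nc1Cl`, in this assay compound 2 is reported as "not determined" (no result reported)
- compound 3, `NC(N)=NC(=O)c1nc(Cl)c(Nc2cnc3ccccc3c2)nc1N`, in this assay compound 3 gives 28%

Compound 2 carries a (tert-butyl)amino group on the shared core and stands without any number in this assay; nothing can be said of where it sits relative to compound 1 or compound 3. The two compounds that do have numbers, compound 1 and compound 3, both carry a substituted amino group at the same position of the core, and their values lie within the scatter of each other, so no order between them is claimed.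

Compound 4, `NC(N)=NC(=O)c1nc(Cl)c(Sc2ccccc2)nc1N`, is to be measured in this assay. It differs from compound 2 in one place: phenylsulfanyl in place of (tert-butyl)amino on an aromatic carbon. Among the measured compounds shown here, no step between measured compounds covers this kind of change, and compound 2 itself has no value, so the size and direction of the step from compound 2 to compound 4 in this assay cannot be read from the series; the only anchors are the two aryl-bearing compounds already measured.

On that basis the inhibition of compound 4 in this assay is expected near that of compound 1 and compound 3, estimated at 30%, with a range from 10% to 55%.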

Compound 4, a percentage reported as inhibition, at one concentration (the size of the read-out at that concentration, not a potency): 11%
Compound 4: the middle estimate sits 19 percentage points above what was measured; measured number inside the range.
By their numbers in this assay, from the lowest: compound 4; then compounds 3 and 1 (each within the scatter of the next).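

Among the compounds shown here, compound 2 has no number in this assay, so compound 4 at 11% yields no step from it, and no new step can be read. No supporting data bear on this result. The compounds shown leave open what phenylsulfanyl in place of (tert-butyl)amino does to inhibition on the shared core.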